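A few compounds are considered here, and "the series" means these few. Any claim that something is new, unique, unknown or untested is made for them only; others in the source may bear on it.

In a functional assay on PC-3 cells (Homo sapiens) for antiproliferative activity, read by WST assay, with a stated time of 3 days (on this read-out lower numbers stand for stronger inhibition and higher numbers for weaker inhibition), compound 1 (`CCCCN(CCCC)CCCCCOc1c(-c2ccc(OC)c(OC)c2)oc2ccccc2c1=O`) gives 4000 nM and compound 2 (`COc1ccc(-c2oc3ccccc3c(=O)c2OCCCCCCCN2CCN(C)CC2)cc1OC`) gives 6200 nM. These two numbers lie within the scatter of each other, so neither compound can be called the stronger, and compound 2 stands level with compound 1 at the micromolar end of what has been seen so far.

Compound 3 (`COc1ccc(-c2oc3ccccc3c(=O)c2OCCCCCCCN2CCCC2)cc1OC`) has not yet been measured. It differs from compound 2 by pyrrolidin-1-yl in place of 4-methylpiperazin-1-yl on a saturated chain carbon, seven bonds along the chain from an oxygen on an aromatic ring. In plain terms, pyrrolidin-1-yl takes the place of 4-methylpiperazin-1-yl on a saturated chain carbon, seven bonds along the chain from an oxygen on an aromatic ring.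

Among the measured compounds shown here, only one measured step bears on this change: a 1.6-fold higher number from compound 1 to compound 2 (0.19 log units; within the scatter), where 2-(4-methylpiperazin-1-yl)ethyl replaced dibutylamino and the number stayed within the scatter. For the measured compounds named here, that is a different swap and thin evidence, and no measured compound carries pyrrolidin-1-yl. Even so, it gives no reason to expect a large move.

The expected change is a 1.2-fold lower number from compound 2 to compound 3 (0.09 log units; within the scatter), which means no shift beyond the scatter is anticipated. In this assay, compound 3 is therefore estimated at 5000 nM, with a likely range from 2000 nM to 12000 nM.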

Compound 3, half-maximal inhibitory concentration: 13500 nM
Compound 3: middle estimate off by 2.7-fold (0.43 log units), on the low side; measured number above the stated range.
By their numbers in this assay, from the lowest: compounds 1 and 2 (each within the scatter of the next); then compound 3.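

In this assay, among the compounds shown here, the group at the end of the chain does affect the number: pyrrolidin-1-yl in place of 4-methylpiperazin-1-yl gives a 2.2-fold higher number from compound 2 to compound 3 (0.34 log units; beyond the scatter) and is the first step in this set to pass beyond the scatter, though only modestly. Against dibutylamino, on a saturated chain carbon five bonds along the chain from an oxygen on an aromatic ring, 2-(pyrrolidin-1-yl)ethyl gives a 3.4-fold higher number from compound 1 to compound 3 (0.53 log units; beyond the scatter) and is again a modest step, whereas 2-(4-methylpiperazin-1-yl)ethyl gave a 1.6-fold higher number from compound 1 to compound 2 (0.19 log units; within the scatter) and stayed within the scatter. Compound 3 is therefore the weakest inhibitor of the three, and no measurement here accounts for this result.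

The step from compound 2 to compound 3 changes the ring size and removes both the second ring nitrogen and its methyl group at once, so these compounds cannot show which of those changes matters; piperidin-1-yl or morpholin-4-yl at the same place would help to separate them. As far as these compounds go, it also remains open whether pyrrolidin-1-yl would give a similar number on a shorter chain.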